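The source may report more compounds than this note shows. Statements on the series, on what has been measured and on what is new or still open speak of the compounds shown alone.

Series notes. Three compounds have numbers in a physicochemical assay, with a stated time of 180 min, tested at 0.5 mg/mL (a higher number here means more inhibition at the concentration tested (going by the name of the read-out), a lower number less inhibition), so far. Compound 1 `O=C(Nc1ccc([Se][Se]c2ccc(NC(=O)OCc3ccccc3)cc2)cc1)OCc1ccccc1` gives 7.4% in this assay. Compound 3 `CCOC(=O)Nc1ccc([Se][Se]c2ccc(NC(=O)OCC)cc2)cc1` gives 37% in this assay. Compound 2 `CCCCOC(=O)Nc1ccc([Se]C#N)cc1` gives 6.6% in this assay and stands at the low end of the three numbers: compound 1 sits within the scatter of it, while compound 3 lies beyond the scatter, a step that is not matched by any single-point comparison among the measured compounds.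

Compound 4 `CC(C)COC(=O)Nc1ccc([Se]C#N)cc1` has not been measured in this assay. It differs from compound 2 in one place only: isopropyl in place of propyl on a saturated chain carbon bound to an oxygen next to a carbonyl group. The carbamate, the shared core and the selenocyanate group are unchanged. Going by the values given here, no measured pair in this assay shows the effect of such a rearrangement of the alkyl chain, so the expectation rests on compound 2 alone. The step from compound 2 to compound 4 is expected to be small, a number 1.4 percentage points higher from compound 2 to compound 4 (within the scatter), in either direction and not beyond the scatter. Compound 4 is therefore estimated at 8% in this assay, with a range from 2% to 18%.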

Compound 4, a percentage reported as inhibition, at one concentration (the size of the read-out at that concentration, not a potency): 27.1%
For compound 4 the middle estimate is 19.1 percentage points below the measured one, and the stated range ends below it.
By their numbers in this assay, from the lowest: compounds 2 and 1 (each within the scatter of the next); then compounds 4 and 3 (each within the scatter of the next).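

In this assay, the alkyl group on the carbamate oxygen of the selenocyanate compounds proves to be a position that responds to branching: isopropyl in place of propyl on a saturated chain carbon bound to an oxygen next to a carbonyl group gives a number 20.5 percentage points higher from compound 2 to compound 4 (beyond the scatter) and thus a step beyond the scatter. The two compounds hold the same atoms joined differently, so butyl to isobutyl alone, with no atom gained or lost, is enough to move this read-out. Nothing available bears on the reason for this step.

Open, going by these compounds, is whether a longer chain, a cyclohexyl group or a terminal amine at this position would move the number further, or back. Also open, on these data alone, is whether the same butyl to isobutyl change would give a similar step on the core of compound 3.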